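Removing a phenyl from the core of a strong kinase inhibitor

A few compounds are considered here, and "the series" means these few. Any claim that something is new, unique, unknown or untested is made for them only; others in the source may bear on it.

Of the compounds shown here, three have been tested in an assay on isolated protein for inhibition of tyrosine-protein kinase receptor UFO (Homo sapiens), read by FRET and Z'-LYTE, with a stated time of 1.5 h; a lower number here means a stronger inhibitor, a higher number a weaker inhibitor. Compound 1 `Cc1ccc2c(c1)c(=O)c(C(=O)Nc1ccc(Oc3ncnc4[nH]cc(-c5ccccc5)c34)c(F)c1)cn2C` gives 150 nM. Compound 2 `Cc1ccc2c(c1)c(=O)c(C(=O)Nc1ccc(Oc3ncnc4[nH]cc(-c5ccccc5)c34)c(F)c1)c(-c1ccccc1)n2C` gives 78 nM. Compound 3 `CCc1ccc2c(c1)c(=O)c(C(=O)Nc1ccc(Oc3ncnc4[nH]cc(-c5ccccc5)c34)c(F)c1)c(C)n2C` gives 6 nM, the lowest of the three numbers, and it stands apart from both others beyond the scatter. Compound 2 and compound 1 differ in one place: hydrogen in place of phenyl on an aromatic carbon. That step, a 1.9-fold higher number from compound 2 to compound 1 (0.28 log units; within the scatter), lies within the scatter. How the core of compound 3 differs from that of compound 2 is not broken down here.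

Compound 4 `CCc1ccc2c(c1)c(=O)c(C(=O)Nc1ccc(Oc3ncnc4[nH]ccc34)c(F)c1)c(C)n2C` is not yet measured in this assay. It differs from compound 3 in one place: hydrogen in place of phenyl on an aromatic carbon. Going by the values given here, this is the same kind of change as the one from compound 2 to compound 1, but not the same change: there the phenyl left an aromatic carbon of a six-membered aromatic ring with one nitrogen, next to the ring nitrogen, whereas here it leaves an aromatic carbon of a five-membered aromatic ring with one nitrogen. Resting on the small earlier step of a 1.9-fold higher number from compound 2 to compound 1 (0.28 log units; within the scatter) and allowing for the different place, the expected step is a 3.3-fold higher number from compound 3 to compound 4 (0.52 log units; beyond the scatter). Compound 4 is thus estimated at 20 nM, expected between 6 nM and 80 nM.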

Compound 4, half-maximal inhibitory concentration: 157 nM
Estimate against measurement, compound 4: 7.9-fold (0.89 log units) below; measured number above the stated range.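

In this assay, taking the phenyl off the aromatic carbon of the five-membered aromatic ring gives a 26-fold higher number from compound 3 to compound 4 (1.42 log units; beyond the scatter), a large loss that the earlier swap of phenyl for hydrogen gave no sign of. The two pairs lose a phenyl from different rings and also differ elsewhere in the core, and two pairs alone cannot show whether the place of the phenyl or the rest of the core sets the size of the step, nor do they explain the gap. What they do show is that this change does not carry over from one core to another with a single size in this series: the same change on two cores in this assay, a 1.9-fold higher number (0.28 log units; within the scatter) from compound 2 to compound 1 and a 26-fold higher number (1.42 log units; beyond the scatter) from compound 3 to compound 4, 14-fold (1.13 log units) apart, beyond the scatter of two such steps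

Only phenyl and hydrogen appear on that carbon of the five-membered ring in the compounds shown, with the phenyl of compound 3 at 6 nM and the hydrogen of compound 4 at 157 nM. Going by these compounds, whether a pyridyl ring, a cyclopropyl ring or a chlorine atom at that place would stay close to compound 3 remains open.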